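Swapping Bromo for Chloro in Compound 1

The compounds below may be only part of what the source reports. "The series", "measured", "known", "first", "only" and "open" are said of these compounds alone.

Measured in an assay on cells for inhibition of Amine oxidase [flavin-containing] B (Homo sapiens), read by fluorescence and Amplex Red, with a stated time of 15 min; a lower number here means a stronger inhibitor, a higher number a weaker inhibitor:
compound 1 `Cc1ccc2oc(=O)c(-c3ccc(Br)nn3)cc2c1`: 2160 nM
compound 2 `COc1ccc2oc(=O)c(-c3ccc(Br)nn3)cc2c1`: 560 nM
compound 3 `COc1cccc2cc(-c3ccc(Br)nn3)c(=O)oc12`: 12900 nM

Among these three numbers compound 1 holds the second highest; compound 2 sits nearer, and compound 3 furthest above it. Going by the values given here, the only single-point step measured, a 3.9-fold lower number from compound 1 to compound 2 (0.59 log units; beyond the scatter), concerns a methoxy in place of methyl and says nothing about the halogen. Compound 4 `Cc1ccc2oc(=O)c(-c3ccc(Cl)nn3)cc2c1` differs from compound 1 by chloro in place of bromo on an aromatic carbon. Among the compounds with values here, no measured step bears on that exchange, so the expectation for compound 4 in this assay is a number close to that of compound 1, with no step beyond the scatter: a 1.1-fold higher number from compound 1 to compound 4 (0.05 log units; within the scatter) is the estimated change. Compound 4 is therefore expected to give 2400 nM, within 900 nM to 6500 nM.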

Compound 4, half-maximal inhibitory concentration: 13500 nM
Compound 4: the middle estimate sits 5.6-fold (0.75 log units) below what was measured; measured number outside the range, above it.
By their numbers in this assay, from the lowest: compound 2; then compound 1; then compounds 3 and 4 (each within the scatter of the next).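

In this assay, chloro in place of bromo on the aromatic carbon next to the ring nitrogen gives a 6.3-fold higher number from compound 1 to compound 4 (0.80 log units; beyond the scatter) and so is not a neutral exchange. The earlier compounds shown here all carried bromo, so they could not show that this position responds to a change of a single halogen atom. Nothing at hand accounts for the difference between the two halogens.

Still open, as far as these compounds go, is how fluoro, iodo or an amine at this position would compare with bromo. From the compounds shown here alone, it is also open whether the same exchange would have a similar effect on the core of compound 2.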